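The source may hold more compounds than are shown below. What is called first, only, known or untested is meant among the compounds shown, and "the series" means these compounds.

For the measured compounds named here, the three compounds measured so far share one core and differ only in the aromatic amine attached to it. Compound 1, `Oc1nc2nonc2nc1Nc1ccc(OC(F)(F)F)c(Cl)c1`, gives 3000 nM in an assay on mitochondria from L6 cells (Rattus norvegicus) for activation, with a stated time of 90 min; on this read-out lower numbers stand for an effect already at smaller amounts and higher numbers for an effect only at larger amounts of compound. Compound 2, `CCCCOc1ccc(Nc2nc3nonc3nc2O)cc1`, gives 3700 nM in this assay. Compound 3, `Oc1nc2nonc2nc1Nc1cccc(OCc2ccc(C(F)(F)F)cc2)c1`, gives 3000 nM in this assay. On these numbers compound 2 stands at the high end of the three, but its distance to compound 1 and its distance to compound 3 both lie within the scatter, so the three compounds cannot be separated from one another on this read-out.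

Compound 4, `CC(C)(C)c1ccc(Nc2nc3nonc3nc2O)cc1`, has not yet been measured. It differs from compound 2 in a single place: tert-butyl in place of butoxy on an aromatic carbon, on an aromatic carbon of a six-membered aromatic ring of carbon only. Going by the values given here, no measured pair here shows what such an exchange does, so the expectation rests only on the three values above, which all sit close together. Compound 4 is therefore expected to stay near compound 2, with an expected step of a 1.1-fold lower number from compound 2 to compound 4 (0.02 log units; within the scatter) that does not reach beyond the scatter. The estimate for compound 4 in this assay is 3500 nM, with a range from 1500 nM to 8000 nM.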

Compound 4, half-maximal effective concentration: 3900 nM
Estimate against measurement, compound 4: 1.1-fold (0.05 log units) below; low and high end bracket the measured number.
By their numbers in this assay, from the lowest: compounds 1, 3, 2 and 4 (each within the scatter of the next).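

In this assay, for the compounds shown here, the exchange of butoxy for tert-butyl on an aromatic carbon, para to a large group, gives a 1.1-fold higher number from compound 2 to compound 4 (0.02 log units; within the scatter), and this is the first step here that can be read between two compounds differing in one place. At this position, the read-out does not separate a chain joined to the ring through oxygen, which counts as a hydrogen-bond acceptor, from an all-carbon branched group without one, so neither that acceptor nor the difference in shape between these two groups shows up as a change in the number. The compounds shown offer no measurement that could explain why the two groups cannot be told apart. Going by these compounds alone, what a group of a different kind would do at this position remains open, for example an amine, a carboxylic acid or a much longer alkyl chain, since butoxy and tert-butyl are the only two groups compared there. Also open, on these data alone, is whether any change at this position can move the number beyond the scatter, as this single step cannot show how far the read-out responds to the group on this aromatic carbon.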